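The source may report more compounds than this note shows. Statements on the series, on what has been measured and on what is new or still open speak of the compounds shown alone.

Measured values in an ADME assay on HepG2 cells (Homo sapiens) for cytotoxicity, read by CellTiter-Glo and resazurin assay, with a stated time of 72 h; a lower number here means that less compound is needed, a higher number that more compound is needed for the effect:
compound 1, `CC(C)N(Cc1cccc(OCCCCCC(=O)O)c1)C(=O)c1ccc(-c2cccc(N(C)C)c2)cc1`, a limit: > 26000 nM.
compound 2, `CC(C)N(Cc1cccc(OCCCCCC(=O)O)c1)C(=O)c1ccc(-c2ccco2)cc1`, a limit: > 26000 nM.
compound 3, `CC(C)N(Cc1cccc(OCCCCCC(=O)O)c1)C(=O)c1ccc(-c2cccc(Oc3ccccc3)c2)cc1`, a limit: > 18700 nM.

Compound 3 stands on a limit of this assay, as the limit of > 18700 nM in this assay, at which 1 of the 3 values shown sits, states. The other two values also sit on a limit, (the limit of > 26000 nM in this assay, at which 2 of the 3 values shown sit). No measured value in this set is a number, so the two single-change steps carry no readable size: a step that the two limits leave unreadable from compound 1 to compound 2 and a step that the two limits leave unreadable from compound 1 to compound 3.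

Compound 4, `Cc1nnc(-c2cccc(-c3ccc(C(=O)N(Cc4cccc(OCCCCCC(=O)O)c4)C(C)C)cc3)c2)o1`, differs from compound 3 by 5-methyl-1,3,4-oxadiazol-2-yl in place of phenoxy on an aromatic carbon. The measured steps that touch the same position of the shared core, from compound 1 to compound 2 and from compound 1 to compound 3, both come out unreadable, so they give no direction and no size for this change in this assay. The expectation for compound 4 is therefore that it will again reach the limit rather than a number, with no step beyond the scatter expected: a step that the limit leaves unreadable from compound 3 to compound 4. Compound 4 is estimated at 30000 nM, with a range from 15000 nM to 100000 nM.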

Compound 4, half-maximal effective concentration: > 26000 nM
Compound 4: no number, only a limit; the forecaster's own chance of this, stated with the estimate: 85%; the middle value lies beyond the limit too.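

In this assay compound 4 gives > 26000 nM, a limit and not a number. Its steps from compound 1, compound 2 and compound 3 cannot be read. The compounds shown leave open at what concentration any of them would give a number, and whether these changes shift it.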